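Swapping a Chloro for an Amino on the Core

This account rests on a few compounds, and the source may have more. Where it says the series, first, only, none or still open, it means among the compounds named here.

Compound 1 `ClCc1ccccc1Cn1cnc2c(Cl)nc(Cl)nc21` gives 450 nM in a functional assay on BT-549 cells (Homo sapiens) for cytotoxicity, read by sulforhodamine B assay, with a stated time of 48 h (a higher number here means a weaker inhibitor of growth, a lower number a stronger inhibitor of growth), the lower of two numbers recorded; compound 2 `ClCc1ccc(Cn2cnc3c(Cl)nc(Cl)nc32)cc1` gives 15900 nM in this assay, a gap beyond the usual scatter. Compound 3 `Nc1nc(Cl)c2ncn(Cc3ccccc3CCl)c2n1` differs from compound 1 by a change at one place, (amino in place of chloro on an aromatic carbon), in words amino in place of chloro on an aromatic carbon. Within the data shown here, no measured pair shows this change, so its direction is unknown; a modest move toward a higher number is expected, a 2.0-fold higher number from compound 1 to compound 3 (0.30 log units; within the scatter). Compound 3 is therefore estimated at 900 nM, within a range from 150 nM to 5000 nM.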

Compound 3, concentration for 50% growth inhibition: 8130 nM
For compound 3 the middle estimate is 9.0-fold (0.96 log units) below the measured one; measured number above the stated range.
By their numbers in this assay, from the lowest: compound 1; then compounds 3 and 2 (each within the scatter of the next).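

On the core of compound 1, the chloro between two ring nitrogen atoms turns out to matter: in this assay, amino in its place gives an 18-fold higher number from compound 1 to compound 3 (1.26 log units; beyond the scatter), a large loss of growth inhibition from a change of one heavy atom. No measurement at hand explains this loss.

From the compounds shown here alone, whether any replacement of this chloro costs as much remains open, since a methoxy, a methylamino or a plain hydrogen at this position could behave differently. The effect of the same swap at the other chloro, meta to this position, is also unknown.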